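This account rests on a few compounds, and the source may have more. Where it says the series, first, only, none or still open, it means among the compounds named here.

The measured compounds:

Compound 1, `O=C1NC(COCc2cc(C(F)(F)F)cc(C(F)(F)F)c2)(c2ccc(F)cc2)CN1C1CCOCC1`, in an assay on CHO cells for displacement of a labelled ligand from Substance-P receptor (Homo sapiens) (a lower number here means a stronger inhibitor, a higher number a weaker inhibitor), compound 1 gives 6.3 nM.
Compound 2, `O=C1NC(COCc2cc(C(F)(F)F)cc(C(F)(F)F)c2)(c2ccc(F)cc2)CN1CCN1CCCC1`, compound 2 gives 1.6 nM.
Compound 3, `O=C1NC[C@@](COCc2cc(C(F)(F)F)cc(C(F)(F)F)c2)(c2ccc(F)cc2)N1`, compound 3 gives 2.7 nM.

Compound 3 sits in the middle of these three numbers. Its value lies within the scatter of that of compound 2, so the two cannot be told apart, while compound 1 gives a higher number than compound 3 by a margin beyond the scatter.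

The unmeasured compound 4, `O=C1NCC(COCc2cc(C(F)(F)F)cc(C(F)(F)F)c2)(c2ccc(F)cc2)N1`, differs from compound 3 only in this way: the two compounds have the same atoms and bonds; at least one stereo element is drawn with a configuration in one of them and without one in the other: 1 of 1 stereo elements differ; a stereocentre at a saturated ring carbon is drawn R in compound 3 and without a configuration in compound 4. Among the measured compounds shown here, the one step measured so far, a 3.9-fold lower number from compound 1 to compound 2 (0.60 log units; beyond the scatter), concerns a change of the group on an amide-type nitrogen in a ring and does not touch the stereocentre, so no measured step bears directly on the change from compound 3 to compound 4. With the same atoms and bonds, compound 4 is expected to give a number close to that of compound 3, and any move is expected to be toward a higher number, as a stereocentre drawn without configuration may include material that does not carry the activity of the drawn form; the estimated step is a 1.7-fold higher number from compound 3 to compound 4 (0.22 log units; within the scatter). Compound 4 is therefore estimated at 4.5 nM, with a range from 2 nM to 12 nM.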

Compound 4, inhibition constant: 4.5 nM
Beside the measured number, compound 4's estimate shows no gap at the digits printed, within the range that was stated.
By their numbers in this assay, from the lowest: compounds 2, 3, 4 and 1 (each within the scatter of the next, the first and the last beyond it).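

In this assay, the step of a 1.7-fold higher number from compound 3 to compound 4 (0.22 log units; within the scatter) gives no sign that drawing the stereocentre with or without a configuration matters here, though the reading of this pair rests on a single difference: the fact that one of compounds 3 and 4 is drawn with a defined configuration and the other without, at the place where they differ. Compound 4 also gives the first reference for this series with hydrogen on the amide-type nitrogen of a compound with no configuration drawn, so that the two groups seen there can now be read against hydrogen. Hydrogen in place of 2-(pyrrolidin-1-yl)ethyl gives a 2.8-fold higher number from compound 2 to compound 4 (0.45 log units; beyond the scatter) and so the basic reading is that this group does stand apart from hydrogen, whereas hydrogen in place of oxan-4-yl gives a 1.4-fold lower number from compound 1 to compound 4 (0.15 log units; within the scatter) and so that group cannot be told apart from hydrogen.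

The compounds shown leave open how the form with the stereocentre drawn S would read in this assay, and so how much of the activity of compound 4 belongs to either form. They also leave open whether the gain seen with 2-(pyrrolidin-1-yl)ethyl would hold for a longer chain, for a piperidine or morpholine in place of the pyrrolidine, or for a carboxylic acid at the end of the chain.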